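Removing a methoxy group: what is expected for compound 3

The source may hold more compounds than are shown below. What is called first, only, known or untested is meant among the compounds shown, and "the series" means these compounds.

Two compounds sharing one core have been examined. Compound 1 `CCOC(=O)/C=C/c1ccc(OC)cc1OC(=O)c1nc(C)c(C)nc1C` and compound 2 `CCOC(=O)/C=C/c1cc(OC)ccc1OC(=O)c1nc(C)c(C)nc1C` carry a methoxy group on different positions of the same ring. In a functional assay on EA.hy 926 cells (Homo sapiens) for cytotoxicity, read by MTT assay, with stated times of 24 h and 12 h, tested at 50 uM (on this read-out lower numbers stand for a weaker effect and higher numbers for a stronger effect at the one concentration tested), compound 1 gives 20.7%, and in this assay compound 2 gives 27.8%. Compound 2 stands alongside compound 1 on these two numbers, the two values differing by an amount that falls within the usual scatter of such measurements, so the two placements of the methoxy group cannot be told apart here.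

The next compound, compound 3 `CCOC(=O)/C=C/c1ccccc1OC(=O)c1nc(C)c(C)nc1C`, is derived from compound 2 by the change (hydrogen in place of methoxy on an aromatic carbon). Within the data shown here, no pair of measured compounds yet shows a step of this kind, so its size must be guessed. Since compound 1 and compound 2 show that moving the methoxy group leaves the read-out essentially unchanged, he expects that removing it altogether will also bring no step beyond the scatter, and the step from compound 2 to compound 3 that he estimates is a number 2.8 percentage points lower from compound 2 to compound 3 (within the scatter). For compound 3 in this assay he estimates 25%, within a range from 12% to 38%.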

Compound 3, a percentage reported as activity, at one concentration (the size of the read-out at that concentration, not a potency): 36.9%
Beside the measured number, compound 3's estimate is 11.9 percentage points below it; the range from low to high includes it.
By their numbers in this assay, from the lowest: compounds 1, 2 and 3 (each within the scatter of the next, the first and the last beyond it).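

In this assay, replacing the methoxy group on the carbon meta to a 2-(ethoxycarbonyl)ethenyl group and para to a large group with hydrogen gives a number 9.1 percentage points higher from compound 2 to compound 3 (within the scatter), so this change at this position does not separate the two compounds. Among these compounds, the same exchange at the other methoxy placement gives a number 16.2 percentage points higher from compound 1 to compound 3 (beyond the scatter), the first step to pass beyond the scatter, although it remains modest. Compound 3, which carries no methoxy group, can therefore be told apart from compound 1 but not from compound 2, something the two methoxy compounds alone could not show.

From the compounds shown here alone, it remains open whether an amine, a hydroxyl group or a fluorine atom at this position would give a step beyond the scatter from compound 3. Going by these compounds, it is equally open how a longer chain in place of the ethoxy part of the 2-(ethoxycarbonyl)ethenyl group would read in this assay. The data at hand offer nothing that bears on the reason for either step.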